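Methyl in Place of Cyclohexyl on a Ring Nitrogen

A few compounds are considered here, and "the series" means these few. Any claim that something is new, unique, unknown or untested is made for them only; others in the source may bear on it.

Compound 1 `Nc1ncnc2c1c(-c1cc(C3CC3)on1)nn2C1CCCCC1` was tested in an ADME assay on BaF3 cells (Mus musculus) for cytotoxicity, read by MTT assay, with a stated time of 48 h; on this read-out lower numbers stand for stronger inhibition of growth and higher numbers for weaker inhibition of growth. In this assay compound 1 gives > 10000 nM, which is a limit of the assay rather than a measured number. Two further compounds sharing the same core were tested the same way. Compound 2 `CC(C)n1nc(/C=N/O)c2c(N)ncnc21` gives > 10000 nM, again a limit. Compound 3 `CC(C)c1cc(-c2nn(C(C)C)c3ncnc(N)c23)no1` gives > 10000 nM, also a limit. Compound 1 therefore stands exactly where the other two stand: none of the three inhibited growth strongly enough for a concentration to be read, a situation summarised by the limit of > 10000 nM in this assay, at which 3 of the 3 values shown sit.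

Compound 4 `Cn1nc(-c2cc(C3CC3)on2)c2c(N)ncnc21` has not yet been measured in this assay. It differs from compound 1 in a single place: methyl in place of cyclohexyl on an aromatic nitrogen. Among the measured compounds shown here, no step between two measured compounds is available here, so the data give no direct guide to how large an effect this kind of change has on growth inhibition. Since all three measured compounds sit at the limit, the step that the limit leaves unreadable from compound 1 to compound 4 is expected to be none beyond the usual scatter. Compound 4 is estimated at 15000 nM, with a range from 5000 nM to 50000 nM, and the result will most likely again be reported only as a limit.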

Compound 4, concentration for 50% growth inhibition: > 10000 nM
Compound 4 gave a limit, no number; the forecaster's own chance of this, stated with the estimate: 85%; the middle value does not contradict the limit.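

In this assay compound 4 gives > 10000 nM, a limit and not a number. Among the compounds shown here, compound 1 gave a limit as well, so no step from compound 1 to compound 4 can be read. The compounds shown leave open how far any change on the shared core moves growth inhibition, as all of them stop at the same point: the limit of > 10000 nM in this assay, at which 4 of the 4 values shown sit.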